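Compound 3 to compound 4: a pyridin-4-yl exchange

A few compounds are considered here, and "the series" means these few. Any claim that something is new, unique, unknown or untested is made for them only; others in the source may bear on it.

In a functional assay on CWR22R cells (Homo sapiens) for antiproliferative activity, read by CCK-8 assay, with a stated time of 6 days (on this read-out lower numbers stand for stronger inhibition and higher numbers for weaker inhibition), compound 3 (`Cn1nccc1-c1cccc2c1CCCN2c1ccc(C#N)c(C(F)(F)F)c1`) gives 10400 nM and sits level, within the scatter, with compound 2 (`N#Cc1ccc(N2CCCc3c(-c4cccnc4)cccc32)cc1C(F)(F)F`) at 12300 nM while compound 1 (`CCN(c1ccc(C#N)c(Cl)c1)c1cc(-c2ccncc2)ccc1C`) shows the lower number of 1030 nM on a different core. Compound 4 (`N#Cc1ccc(N2CCCc3c(-c4ccncc4)cccc32)cc1C(F)(F)F`) has pyridin-4-yl in place of 1-methyl-1H-pyrazol-5-yl on an aromatic carbon. For the measured compounds named here, the one measured step on this core (a 1.2-fold lower number from compound 2 to compound 3 (0.07 log units; within the scatter)) stayed within the scatter, so exchanging the aromatic ring at this carbon has so far left the number unmoved. Compound 1 also carries pyridin-4-yl, but its core differs, so its 1030 nM offers only a weak hint toward a lower number. No step beyond the scatter is expected in this assay and the estimated change is a 1.3-fold lower number from compound 3 to compound 4 (0.11 log units; within the scatter) with a slight lean toward the lower number. Compound 4 is estimated at 8000 nM with an expected range of 3000 nM to 20000 nM for the measurement.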

Compound 4, half-maximal inhibitory concentration: 15000 nM
The estimate for compound 4 lay 1.9-fold (0.27 log units) below the measured number, and the stated range covers the measured number.
By their numbers in this assay, from the lowest: compound 1; then compounds 3, 2 and 4 (each within the scatter of the next).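

In this assay, pyridin-4-yl in place of 1-methyl-1H-pyrazol-5-yl on an aromatic carbon gives a 1.4-fold higher number from compound 3 to compound 4 (0.16 log units; within the scatter), and pyridin-4-yl in place of pyridin-3-yl gives a 1.2-fold higher number from compound 2 to compound 4 (0.09 log units; within the scatter). Compounds 2, 3 and 4 therefore stand level within the scatter, so this read-out separates neither the two pyridine attachments nor the pyridine and pyrazole rings at this carbon of the shared core. Nothing at hand gives a reason for this flat response.

As far as these compounds go, whether a group of another kind at this carbon, such as an amine, a carboxylic acid or a longer alkyl chain, would move the number beyond the scatter remains open. For the compounds shown here, also open is the origin of the lower number of compound 1 at 1030 nM, which no single-place step connects to the shared core.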